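The compounds below may be only part of what the source reports. "The series", "measured", "known", "first", "only" and "open" are said of these compounds alone.

Measured in a functional assay on NCI-H460 cells (Homo sapiens) for antiproliferative activity, read by MTT assay, with a stated time of 72 h; on this read-out lower numbers stand for stronger inhibition and higher numbers for weaker inhibition:
- compound 1 `O=c1c(-c2ccc(F)cc2)c[nH]c2ccnc(Nc3ccc(Oc4ccnc5cc(OCCO)ccc45)c(F)c3)c12`: 3500 nM
- compound 2 `CC(C)(O)COc1ccc2c(Oc3ccc(Nc4nccc5[nH]cc(-c6ccc(F)cc6)c(=O)c45)cc3F)ccnc2c1`: 3200 nM
- compound 3 `COC(C)(C)COc1ccc2c(Oc3ccc(Nc4nccc5[nH]cc(-c6ccc(F)cc6)c(=O)c45)cc3F)ccnc2c1`: 4400 nM

Compound 3 gives 4400 nM, and the other two compounds do not separate from it. The steps to it are a 1.3-fold higher number from compound 1 to compound 3 (0.10 log units; within the scatter) and a 1.4-fold higher number from compound 2 to compound 3 (0.14 log units; within the scatter). The three values therefore form a single group in this assay.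

Compound 4 `COCCOc1ccc2c(Oc3ccc(Nc4nccc5[nH]cc(-c6ccc(F)cc6)c(=O)c45)cc3F)ccnc2c1` keeps the shared core and changes only the end of the chain: methoxymethyl in place of 1-methoxy-1-methylethyl on a saturated chain carbon bound to an oxygen on an aromatic ring. In words, this is methoxymethyl in place of 1-methoxy-1-methylethyl on a saturated chain carbon bound to an oxygen on an aromatic ring.

Within the data shown here, two measured steps bear on this change. The closest parallel is the same swap of chain ends run in the opposite direction on the hydroxy-ended chains, which gave a 1.1-fold lower number from compound 1 to compound 2 (0.04 log units; within the scatter). Placing a methyl on the chain oxygen gave a 1.4-fold higher number from compound 2 to compound 3 (0.14 log units; within the scatter). Neither step leaves the scatter, so no step beyond the scatter is expected in this assay, and the data favour no direction.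

The expected change is a 1.2-fold lower number from compound 3 to compound 4 (0.06 log units; within the scatter). For compound 4 the estimated value is 3800 nM, with an expected range from 2000 nM to 7000 nM.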

Compound 4, half-maximal inhibitory concentration: 4300 nM
Compound 4: the middle estimate sits 1.1-fold (0.05 log units) below what was measured, within the range that was stated.
By their numbers in this assay, from the lowest: compounds 2, 1, 4 and 3 (each within the scatter of the next).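

In this assay, going from 2-methoxy-2-methylpropyl to 2-methoxyethyl gives a 1.0-fold lower number from compound 3 to compound 4 (0.01 log units; within the scatter), so with the chain oxygen capped by a methyl, the branched and unbranched chain ends cannot be told apart, a point the earlier compounds had shown only for the hydroxy-ended pair. Changing the branching and the capping together also stays small, with a 1.3-fold higher number from compound 2 to compound 4 (0.13 log units; within the scatter), so among these four compounds neither change, alone or combined, moves the number beyond the scatter. Compound 4 also gives a second reading of a methyl placed on the chain oxygen, a 1.2-fold higher number from compound 1 to compound 4 (0.09 log units; within the scatter), and this agrees with the first reading, so the capping step is now seen twice rather than once: the same change on two cores in this assay, a 1.4-fold higher number (0.14 log units; within the scatter) from compound 2 to compound 3 and a 1.2-fold higher number (0.09 log units; within the scatter) from compound 1 to compound 4, 1.1-fold (0.05 log units) apart, within the scatter of two such steps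

All four chains shown end in a hydroxyl or a methoxy group, so it remains open whether a chain ending in an amine or a carboxylic acid, or a longer chain, would shift the number beyond the scatter. The rest of the molecule is the same in all four compounds, so they also cannot tell whether this insensitivity would hold if the 4-fluorophenyl group were replaced.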